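Adding a Methoxy to the Carbonyl-Side Aryl of a Pyrazole Chalcone

A few compounds are considered here, and "the series" means these few. Any claim that something is new, unique, unknown or untested is made for them only; others in the source may bear on it.

Measured so far:
Compound 1, `COc1cc(-c2cc(/C=C/C(=O)c3ccc(Cl)c(Cl)c3)[nH]n2)cc(OC)c1OC`, gives 90% in a functional assay on UACC-257 cells (Homo sapiens) for cytotoxicity, read by sulforhodamine B assay, with a stated time of 48 h, tested at 1 uM; a lower number here means a stronger effect, a higher number a weaker effect of the compound at the concentration tested.
Compound 2, `COc1ccc(C(=O)/C=C/c2cc(-c3cc(OC)c(OC)c(OC)c3)n[nH]2)cc1OC`, gives 81% in this assay.

Among the compounds with values here, compound 2 stands within the scatter of compound 1: the only known step, a number 9 percentage points lower from compound 1 to compound 2 (within the scatter), swaps the aryl on the carbonyl carbon without a change beyond the scatter. Compound 3, `COc1cc(C(=O)/C=C/c2cc(-c3cc(OC)c(OC)c(OC)c3)n[nH]2)cc(OC)c1OC`, differs from compound 2 by methoxy in place of hydrogen on an aromatic carbon. Within the data shown here, no measured step adds a methoxy on that ring, and the one step touching that aryl was within the scatter, so a step of a number 3 percentage points higher from compound 2 to compound 3 (within the scatter) is expected, none beyond the scatter. Compound 3 is therefore estimated at 84%, between 68% and 100%.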

Compound 3, a percentage reported as activity, at one concentration (the size of the read-out at that concentration, not a potency): 85%
Compound 3: the middle estimate sits 1 percentage points below what was measured; measured number inside the range.
By their numbers in this assay, from the lowest: compounds 2, 3 and 1 (each within the scatter of the next).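

In this assay, adding a methoxy on an aromatic carbon, ortho to a methoxy group and meta to a large group, gives a number 4 percentage points higher from compound 2 to compound 3 (within the scatter) and so leaves the read-out at the tested concentration unchanged beyond the scatter. Within the data shown here, this is the first measured step that adds a single group to the carbonyl-side aryl rather than exchanging the whole aryl. Going by these compounds, it remains open whether an amine or a carboxylic acid at this place, or a longer chain in place of the methoxy, would give a step beyond the scatter. No measurement at hand offers an explanation for this result.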